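A few compounds are considered here, and "the series" means these few. Any claim that something is new, unique, unknown or untested is made for them only; others in the source may bear on it.

Of the compounds shown here, three have been measured in an ADME assay on L1210/0 cells (Mus musculus) for cytotoxicity, with a stated time of 48 h; a higher number here means a weaker inhibitor, a lower number a stronger inhibitor. Compound 1, `CC1(C)[C@@H](Cn2cnc3c(Cl)nc(N)nc32)CC[C@@]1(C)CO`, gives 50000 nM in this assay. Compound 2, `O=c1[nH]c(=O)n([C@H]2C[C@H](O)[C@@H](CO)O2)cc1/C=N/O`, gives 15500 nM in this assay. Compound 3, `Cc1ccc(C(=O)/C=C/c2cc(O)nc(O)n2)cc1`, gives 182000 nM in this assay. Of the three numbers, compound 2 has the lowest, so it is the strongest inhibitor of the set: the gap to compound 1 is already beyond the usual scatter of repeated measurements, and the gap to compound 3 is wider still.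

The next compound, compound 4, `O=c1[nH]c(=O)n([C@H]2C[C@H](O)[C@@H](CO)O2)cc1C#CCCO`, is not yet measured. It is built from compound 2 by one change on the shared core: a group of 5 heavy atoms (4 carbon, 1 oxygen; no ring) in place of a group of 3 heavy atoms (1 carbon, 1 nitrogen, 1 oxygen; no ring), on an aromatic carbon. The group that enters, 4-hydroxybut-1-yn-1-yl, keeps one hydrogen-bond donor but carries a triple bond rather than a double bond and holds one acceptor fewer.

Among the measured compounds shown here, no pair of measured compounds differing in a single place is available, so there is no directly comparable step to lean on. Given that, the step from compound 2 to compound 4 is expected to be modest, in the direction of a somewhat higher number, roughly a 1.9-fold higher number from compound 2 to compound 4 (0.29 log units; within the scatter). Compound 4 is therefore estimated at 30000 nM in this assay, with a plausible range from 8000 nM to 120000 nM.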

Compound 4, half-maximal inhibitory concentration: > 200000 nM
Compound 4 ended at the assay's limit; the forecaster's own chance of this, stated with the estimate: 15%; middle value at least 6.6-fold (0.82 log units) from the limit.
By their numbers in this assay, from the lowest: compound 2; then compound 1; then compound 3. At a limit, above all of these: compound 4.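

Among the compounds shown here, this is the first step in the set that can be read at a single place, on an aromatic carbon of a six-membered aromatic ring, and it is large: putting 4-hydroxybut-1-yn-1-yl in place of the group of compound 2 gives an at least 12-fold higher number from compound 2 to compound 4 (1.11 log units; beyond the scatter). The earlier compounds shown here differ from one another in more than one place, so they could not show that a change at this position alone can move the read-out this far, even though the entering group keeps the same count of hydrogen-bond donors. In this assay compound 4 gives > 200000 nM, which is a limit of the assay and not a number, and it is the only such reading in the set: the limit of > 200000 nM in this assay, at which 1 of the 4 values shown sits.

The entering group differs from the one that leaves in size, in its triple bond and in its count of acceptors all at once, so the compounds shown cannot tell which of these differences goes with the step. They also leave open how this position would read with a plain ethyl group, a longer chain or a chain ending in an amine.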